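A Bicyclic Amide Replaces a Vinyl Ester

The source may hold more compounds than are shown below. What is called first, only, known or untested is meant among the compounds shown, and "the series" means these compounds.

Compound 3 `C=CC(=O)Oc1cc2c(Nc3ccc(Cl)c(Cl)c3F)ncnc2cc1OC` gives 1350 nM in a functional assay on Calu-3 cells (Homo sapiens) for antiproliferative activity, read by CCK-8 assay, with a stated time of 72 h (a lower number here means a stronger inhibitor of growth, a higher number a weaker inhibitor of growth), the highest of the three numbers measured. Compound 1 `C=C(C(=O)N1CCN(C(=O)Oc2cc3c(Nc4ccc(Cl)c(Cl)c4F)ncnc3cc2OC)[C@H](C)C1)C(F)(F)F` gives 553 nM and compound 2 `C#CC(=O)N1CCN(C(=O)Oc2cc3c(Nc4ccc(Cl)c(Cl)c4F)ncnc3cc2OC)[C@H](C)C1` gives 718 nM. Compound 4 `C=CC(=O)N1C[C@@H]2C[C@H]1CN2C(=O)Oc1cc2c(Nc3ccc(Cl)c(Cl)c3F)ncnc2cc1OC` differs from compound 3 by a group of 11 heavy atoms (8 carbon, 2 nitrogen, 1 oxygen; 2 five-membered non-aromatic rings with 1 hetero atom each) in place of a group of 2 heavy atoms (2 carbon; no ring), on a carbonyl carbon. The closest measured step runs the other way: a 1.9-fold higher number from compound 2 to compound 3 (0.27 log units; within the scatter), where a cyclic amine carrying its own carbonyl gave way to a plain vinyl group. The other step, a 1.3-fold higher number from compound 1 to compound 2 (0.11 log units; within the scatter), shows that the exact group on that carbonyl carbon hardly altered the outcome. The move to compound 4 brings back a ring-bound amide, so a modest fall in number is expected, a 1.9-fold lower number from compound 3 to compound 4 (0.29 log units; within the scatter). Compound 4 is estimated at 700 nM, within 300 nM to 1600 nM.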

Compound 4, concentration for 50% growth inhibition: 23.1 nM
Beside the measured number, compound 4's estimate is 30-fold (1.48 log units) above it; measured number outside the range, below it.
By their numbers in this assay, from the lowest: compound 4; then compounds 1, 2 and 3 (each within the scatter of the next, the first and the last beyond it).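

In this assay, the group on this carbonyl carbon matters far more than compound 1, compound 2 and compound 3 suggested: a 58-fold lower number from compound 3 to compound 4 (1.77 log units; beyond the scatter). A ring-bound amide alone does not account for this, as a 31-fold lower number from compound 2 to compound 4 (1.49 log units; beyond the scatter), a change that replaces the six-membered ring with the two five-membered rings and also ethynyl with vinyl.

Still open, on these data alone, is which of those two replacements carries the gain, which the same bicyclic group bearing ethynyl, or a piperazine bearing vinyl, would help separate. No measurement shown here accounts for the size of the gain.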